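The source may report more compounds than this note shows. Statements on the series, on what has been measured and on what is new or still open speak of the compounds shown alone.

Measured in a functional assay on KB 3-1 cells (Homo sapiens) for cytotoxicity, read by MTT assay, with a stated time of 68 h; on this read-out higher numbers stand for weaker inhibition and lower numbers for stronger inhibition:
compound 1 `COc1ccc(-c2cc(NC(=O)C(Cl)Cl)cc(-c3ccc(OC)cc3)c2)cc1`: > 30000 nM, a limit
compound 2 `COc1ccc(-c2cccc(NC(=O)C(Cl)Cl)c2)cc1`: > 50000 nM, a limit

Compound 2 stands at > 50000 nM, which is a limit and not a number. Compound 1 also offers only a limit: the limit of > 30000 nM in this assay, at which 1 of the 2 values shown sits.

Compound 3 `O=C(Nc1cccc(-c2ccc(-c3ccccc3)cc2)c1)C(Cl)Cl` departs from compound 2 by phenyl in place of methoxy on an aromatic carbon, para to a large group.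

Among the compounds with values here, the only measured step, a step that the two limits leave unreadable from compound 1 to compound 2, is a different change, hydrogen in place of 4-methoxyphenyl, and its size cannot be read. It gives no size to carry over. With only limits in this assay, no step beyond the scatter is expected, and another limit is the likeliest report. The expected step is an at least 1.2-fold lower number from compound 2 to compound 3 (0.09 log units; that floor lies within the scatter). For compound 3 the estimate is 40000 nM, with an expected range of 10000 nM to 100000 nM.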

Compound 3, half-maximal inhibitory concentration: > 50000 nM
Compound 3: a limit, no number (the forecaster's own chance of this, stated with the estimate: 65%); middle value at least 1.2-fold (0.09 log units) from the limit.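

In this assay compound 3 gives > 50000 nM, a limit and not a number. Compound 2 also offers only a limit, and no step can be read between compound 2 and compound 3. The compounds shown leave open whether phenyl in place of methoxy changes the read-out at all.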